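Adding one carbon to the aminocyclohexyl group

The source may report more compounds than this note shows. Statements on the series, on what has been measured and on what is new or still open speak of the compounds shown alone.

Within the data shown here, in a functional assay on MV4-11 cells (Homo sapiens) for antiproliferative activity, read by CellTiter-Glo, with a stated time of 72 h (on this read-out lower numbers stand for stronger inhibition of growth and higher numbers for weaker inhibition of growth), compound 1 `O=C(Nc1cc(-c2csc(NCC3CCOCC3)n2)c(Cl)cn1)c1ccc(F)cc1` gives 550 nM and compound 2 `N[C@H]1CC[C@H](Nc2cc(-c3csc(NCC4CCOCC4)n3)c(Cl)cn2)CC1` gives 140 nM, the lower of the two numbers so far. Compound 3 `N[C@H]1CC[C@H](CNc2cc(-c3csc(NCC4CCOCC4)n3)c(Cl)cn2)CC1` carries (4-aminocyclohexyl)methyl in place of 4-aminocyclohexyl on a nitrogen on an aromatic ring. Among the measured compounds shown here, the only measured step at this nitrogen is modest: a 3.9-fold lower number from compound 1 to compound 2 (0.59 log units; beyond the scatter). That step replaced (4-fluorophenyl)carbonyl with 4-aminocyclohexyl, whereas the new change retains the six-membered non-aromatic ring of carbon only, so it gives limited guidance. No step beyond the scatter is expected in this assay, with a slight lean towards a higher number. The estimated step is a 1.2-fold higher number from compound 2 to compound 3 (0.08 log units; within the scatter). With compound 2 at 140 nM as the anchor, the range is kept wide. The expected value for compound 3 is 170 nM, with an estimated range of 60 nM to 480 nM.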

Compound 3, concentration for 50% growth inhibition: 1900 nM
For compound 3 the middle estimate is 11-fold (1.05 log units) below the measured one; measured number above the stated range.
By their numbers in this assay, from the lowest: compound 2; then compound 1; then compound 3.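

In this assay, among these compounds, this nitrogen on an aromatic ring proves sensitive to a single added carbon: (4-aminocyclohexyl)methyl in place of 4-aminocyclohexyl gives a 14-fold higher number from compound 2 to compound 3 (1.13 log units; beyond the scatter), a large step, where the only earlier step here was modest. The six-membered non-aromatic ring and its amine therefore do not secure the lower number on their own, and the series also gives a 3.5-fold higher number from compound 1 to compound 3 (0.54 log units; beyond the scatter), so the (4-fluorophenyl)carbonyl compound keeps the lower number of that pair. Nothing available bears on the reason for the large step.

Open, on these data alone, is whether the trend continues with a longer chain, such as 2-(4-aminocyclohexyl)ethyl, on this nitrogen. Also open, as far as these compounds go, is how much of the step depends on the amine, which 4-hydroxycyclohexyl or (4-hydroxycyclohexyl)methyl on this nitrogen would help to separate.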